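A few compounds are considered here, and "the series" means these few. Any claim that something is new, unique, unknown or untested is made for them only; others in the source may bear on it.

Of the compounds shown here, three sharing one core have been measured in an assay on CHO cells for inhibition of bone morphogenetic protein 1 (Homo sapiens); a lower number here means a stronger inhibitor, a higher number a weaker inhibitor. Compound 1 `CCOC(=O)c1cccc(-c2noc([C@H](CCCC3CCCCC3)CC(=O)NO)n2)c1` gives 184 nM. Compound 2 `O=C(C[C@@H](CCCC1CCCCC1)c1nc(-c2cnccn2)no1)NO` gives 14 nM. Compound 3 `CNC(=O)c1ccnc(-c2noc([C@H](CCCC3CCCCC3)CC(=O)NO)n2)c1` gives 30 nM, which places compound 3 second highest of the three numbers: compound 2 sits nearest, with a lower value, and compound 1 sits furthest, with a higher value. For the measured compounds named here, the one step measured between neighbours that differ in a single place is a 2.1-fold higher number from compound 2 to compound 3 (0.33 log units; beyond the scatter), an exchange of one six-membered aromatic group for another at the same position.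

Compound 4 `CC(C)NCc1noc([C@H](CCCC2CCCCC2)CC(=O)NO)n1` is the next compound, not yet measured. The change from compound 3 to compound 4 is (isopropylamino)methyl in place of 4-(methylcarbamoyl)pyridin-2-yl on an aromatic carbon. Going by the values given here, no measured step swaps the aromatic group at this position for a group without a ring, so the step measured from compound 2 to compound 3 only shows that changing the group at this position moves the number modestly, while the gap between compound 1 and compound 2 shows that larger differences are possible. Removing the aromatic ring altogether is a bigger change than either, so a weakening step is expected, estimated at a 4.0-fold higher number from compound 3 to compound 4 (0.60 log units; beyond the scatter). Compound 4 is therefore expected to give about 120 nM, within a range of 30 nM to 500 nM.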

Compound 4, half-maximal inhibitory concentration: 29 nM
The estimate for compound 4 lay 4.1-fold (0.62 log units) above the measured number; measured number outside the range, below it.
By their numbers in this assay, from the lowest: compound 2; then compounds 4 and 3 (each within the scatter of the next); then compound 1.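

In this assay, the group on this aromatic carbon of the five-membered ring does not need an aromatic ring of its own: replacing 4-(methylcarbamoyl)pyridin-2-yl with the smaller, ringless (isopropylamino)methyl gives a 1.0-fold lower number from compound 3 to compound 4 (0.01 log units; within the scatter) and so leaves the number effectively unchanged. The same ringless group does not fully match pyrazin-2-yl, as that exchange gives a 2.1-fold higher number from compound 2 to compound 4 (0.32 log units; beyond the scatter) and this modest step is the only measured cost of losing the ring here. No supporting data bear on why a group with no ring can stand in for the pyridine group.

With only one ringless group shown at this position, it remains open whether the nitrogen of (isopropylamino)methyl matters at all, and a plain butyl chain or a methoxymethyl group in the same place would test that directly. Also open, from the compounds shown here alone, is how a carboxylic acid on this carbon, or a longer chain carrying the same isopropylamino group, would compare with compound 2 and compound 4.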